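This account rests on a few compounds, and the source may have more. Where it says the series, first, only, none or still open, it means among the compounds named here.

Measured compounds:
Compound 1 `CCCCOc1ccc(C(=O)NNC(=O)c2cccc(NS(=O)(=O)c3cnc(O)nc3O)c2)cc1`, 9200 nM.
Compound 2 `Cc1ccccc1C(=O)NNC(=O)c1cccc(NS(=O)(=O)c2cnc(O)nc2O)c1`, > 20000 nM, which is a limit of the assay and not a number.
Compound 3 `CCCCOc1ccc(C(=O)NNC(=O)c2ccccc2NS(=O)(=O)c2cnc(O)nc2O)cc1`, 5010 nM.

These values come from a functional assay on OVCAR-3 cells (Homo sapiens) for antiproliferative activity, read by MTT assay, with a stated time of 24 h; a higher number here means a weaker inhibitor, a lower number a stronger inhibitor. Compound 1 and compound 2 share a core and differ only in that (2-methylphenyl in place of 4-butoxyphenyl on a carbonyl carbon). The step of an at least 2.1-fold higher number from compound 1 to compound 2 (0.33 log units; beyond the scatter) is known only in part, because compound 2 sits at the limit of > 20000 nM in this assay, at which 1 of the 3 values shown sits. Compound 3 has the same atoms as compound 1 joined differently; the difference between the two cores is not broken down here. Compound 3 and compound 1 give numbers within the scatter of each other in this assay.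

Compound 4 `Cc1ccccc1C(=O)NNC(=O)c1ccccc1NS(=O)(=O)c1cnc(O)nc1O` is not yet measured. It differs from compound 3 by the same change: 2-methylphenyl in place of 4-butoxyphenyl on a carbonyl carbon. The step expected in this assay is a 3.0-fold higher number from compound 3 to compound 4 (0.48 log units; beyond the scatter), resting on the earlier at least 2.1-fold higher number from compound 1 to compound 2 (0.33 log units; beyond the scatter) and on the chance that compound 4 also reaches (the limit of > 20000 nM in this assay, at which 1 of the 3 values shown sits). Compound 4 is therefore estimated at 15000 nM, with a range from 6000 nM to 40000 nM.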

Compound 4, half-maximal inhibitory concentration: > 20000 nM
Compound 4: only a limit was reported; the forecaster's own chance of this, stated with the estimate: 55%; middle value at least 1.3-fold (0.12 log units) away from the limit.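

Compound 4 gives > 20000 nM in this assay, and this is a limit of the assay, not a number. Putting 2-methylphenyl in place of 4-butoxyphenyl on a carbonyl carbon therefore gives an at least 3.9-fold higher number from compound 3 to compound 4 (0.60 log units; beyond the scatter), so on this second core the change again moves the number up, beyond the scatter. This shows that the direction of the change carries over between the two cores, but it does not show that its size carries over: the same change on two cores in this assay, an at least 2.1-fold higher number (0.33 log units; beyond the scatter) from compound 1 to compound 2 and an at least 3.9-fold higher number (0.60 log units; beyond the scatter) from compound 3 to compound 4; the limit leaves it open whether they differ.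

As far as these compounds go, both compounds with 2-methylphenyl sit at the limit, so how far the number really rises on either core stays open: the limit of > 20000 nM in this assay, at which 2 of the 4 values shown sit. From the compounds shown here alone, it also remains open whether the butoxy chain itself matters, and whether a longer chain, an amine or a carboxylic acid in its place on the phenyl ring would keep the numbers close to those of compound 1 and compound 3.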